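From Methyl to Chloro: An Expected Shift

This account rests on a few compounds, and the source may have more. Where it says the series, first, only, none or still open, it means among the compounds named here.

Results in a functional assay on MDA-MB-231 cells (Homo sapiens) for cytotoxicity, read by MTT assay, with a stated time of 48 h; a higher number here means a weaker inhibitor, a lower number a stronger inhibitor:
Compound 1 `CC(C)n1c(/C=C2/C(=O)Nc3ccc(Br)cc32)nc2ccccc21`: 3260 nM
Compound 2 `CCn1c(/C=C2/C(=O)Nc3ccc(C)cc32)nc2ccccc21`: 40600 nM
Compound 3 `Cn1c(/C=C2/C(=O)Nc3ccc([N+](=O)[O-])cc32)nc2ccccc21`: "not determined" (no result reported)

Only two of these compounds have a number. Compound 2, at 40600 nM, holds the higher one, so it is the weaker inhibitor of the pair. Compound 1 reads lower at 3260 nM, and this gap lies beyond the usual scatter. Compound 3 offers no number for comparison.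

The next compound to be tested is compound 4 `CCn1c(/C=C2/C(=O)Nc3ccc(Cl)cc32)nc2ccccc21`, which has chloro in place of methyl on an aromatic carbon of compound 2: chloro in place of methyl on an aromatic carbon. Among the compounds with values here, no measured pair isolates this change, so the data give no direct size for it. The only hint of direction comes from compound 1, which also bears a halogen and reads 3260 nM. It is a weak guide, since it is not otherwise identical to compound 2. A moderate fall in the number is therefore expected in this assay, beyond the scatter but uncertain in size. The estimated change is a 3.4-fold lower number from compound 2 to compound 4 (0.53 log units; beyond the scatter). For compound 4 the expected value is 12000 nM, with an estimated range of 4000 nM to 35000 nM.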

Compound 4, half-maximal inhibitory concentration: 37500 nM
Compound 4: middle estimate off by 3.1-fold (0.49 log units), on the low side; measured number outside the range, above it.
By their numbers in this assay, from the lowest: compound 1; then compounds 4 and 2 (each within the scatter of the next).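

In this assay, within the data shown here, the step of a 1.1-fold lower number from compound 2 to compound 4 (0.03 log units; within the scatter) comes with chloro in place of methyl on this aromatic carbon, and it is the first measured pair to isolate this position. With the ethyl group and the rest of the shared core held constant, the two compounds cannot be told apart in this read-out, so at this position the exchange of one single-atom group for the other has no measurable effect on the number, and the hint drawn from the halogen of compound 1 does not hold for this pair. Nothing on hand offers any measured explanation for this outcome.

Compound 1, at 3260 nM, differs from compound 4 in more than one place, so the compounds shown do not tell which of its features goes with its number. They also leave open how an amine or a methoxy group on this same aromatic carbon, or a longer chain in place of the ethyl group, would read in this assay, and whether any such group would move the number beyond the scatter.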